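This account rests on a few compounds, and the source may have more. Where it says the series, first, only, none or still open, it means among the compounds named here.

Three compounds share one core and differ only in the group attached to the piperazine. Compound 1 `COc1ccc(C(=O)N2CCN(c3nc(N)c4cc(OC)c(OC)cc4n3)CC2)cc1OC` carries a 3,4-dimethoxyphenyl on a carbonyl carbon, and in a functional assay on PC-3 cells (Homo sapiens) for inhibition (on this read-out higher numbers stand for weaker inhibition and lower numbers for stronger inhibition), compound 1 gives 71000 nM. Compound 2 `COc1cc2nc(N3CCN(C(=O)c4cccc5ccccc45)CC3)nc(N)c2cc1OC` has a naphthalen-1-yl in that place; in this assay compound 2 gives 59000 nM, so there is a 1.2-fold lower number from compound 1 to compound 2 (0.08 log units; within the scatter). Compound 3 `COc1ccc(S(=O)(=O)N2CCN(c3nc(N)c4cc(OC)c(OC)cc4n3)CC2)cc1` instead bears a 4-methoxyphenyl on a sulfonyl sulfur, and in this assay compound 3 gives 39000 nM. This puts compound 3 at the low end of the three numbers, with compound 2 and compound 1 each within the scatter of it.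

Compound 4 `COc1cc2nc(N3CCN(S(=O)(=O)c4cccc5ccccc45)CC3)nc(N)c2cc1OC` differs from compound 3 in one place: naphthalen-1-yl in place of 4-methoxyphenyl on a sulfonyl sulfur. Among the compounds with values here, the only measured step that bears on this is the one from compound 1 to compound 2, where the same naphthalen-1-yl entered on a carbonyl carbon and the number moved within the scatter. The change on the sulfonyl sulfur is therefore expected to give a step of a 1.1-fold lower number from compound 3 to compound 4 (0.05 log units; within the scatter), again within the scatter. For compound 4 in this assay the estimate is 35000 nM, with a range from 15000 nM to 80000 nM.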

Compound 4, half-maximal inhibitory concentration: 14000 nM
Estimate against measurement, compound 4: 2.5-fold (0.40 log units) above; the measured number lies below the stated range.
By their numbers in this assay, from the lowest: compound 4; then compounds 3, 2 and 1 (each within the scatter of the next).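

In this assay, the group on the sulfonyl sulfur clearly matters, with naphthalen-1-yl replacing 4-methoxyphenyl giving a 2.8-fold lower number from compound 3 to compound 4 (0.44 log units; beyond the scatter). On a carbonyl carbon, the same group gave only a 1.2-fold lower number from compound 1 to compound 2 (0.08 log units; within the scatter), but it replaced 3,4-dimethoxyphenyl there, so the two steps differ in the group that leaves as well as in the atom that carries the new one. Nothing shown here explains why the number moved in one case and stayed within the scatter in the other.

Going by these compounds, it remains open whether the lower number comes from the second aromatic ring that enters or from the loss of the methoxy group. A plain phenyl on the sulfonyl sulfur would help separate the two, while naphthalen-2-yl or a ring carrying an amine or a carboxylic acid would show how much else this place accepts.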